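Dimethylphenyl swap on the shared core: compound 3

The compounds below may be only part of what the source reports. "The series", "measured", "known", "first", "only" and "open" are said of these compounds alone.

In a functional assay on T-24 cells (Homo sapiens) for antiproliferative activity, read by MTT assay, with a stated time of 48 h (on this read-out lower numbers stand for stronger inhibition and higher numbers for weaker inhibition), compound 1 (`COc1ccccc1NC(=O)Nc1cccc(CNc2nccnc2Cl)c1`) gives 10400 nM and compound 2 (`Cc1ccc(NC(=O)Nc2cccc(CNc3nccnc3Cl)c2)c(C)c1`) gives 9230 nM and the two stand level. Among the compounds with values here, compound 2 therefore sits with compound 1 on the numbers so far, with no separation beyond the scatter.

Compound 3 (`Cc1ccc(NC(=O)Nc2cccc(CNc3nccnc3Cl)c2)cc1C`) differs from compound 2 as follows: 3,4-dimethylphenyl in place of 2,4-dimethylphenyl on an amide-type nitrogen. The two have the same atoms, joined differently.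

Within the data shown here, only one measured step bears on this change, a 1.1-fold lower number from compound 1 to compound 2 (0.05 log units; within the scatter), made at the same amide-type nitrogen. Among the measured compounds shown here, no measured step compares two compounds with the same atoms joined differently, so this guide is indirect.

An estimated 1.0-fold lower number from compound 2 to compound 3 (0.01 log units; within the scatter) is expected in this assay with no direction beyond the scatter. Compound 3 is expected at 9000 nM with an estimated range of 4000 nM to 18000 nM in this read-out.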

Compound 3, half-maximal inhibitory concentration: 8930 nM
Estimate against measurement, compound 3: 1.0-fold (0.00 log units) above, and the stated range covers the measured number.
By their numbers in this assay, from the lowest: compounds 3, 2 and 1 (each within the scatter of the next).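

Swapping the 2,4-dimethylphenyl for 3,4-dimethylphenyl on the amide-type nitrogen gives a 1.0-fold lower number from compound 2 to compound 3 (0.01 log units; within the scatter) in this assay, so rearranging the two methyl groups on this ring opens no separation. Within the data shown here, the comparison with the methoxy-bearing group gives a 1.2-fold lower number from compound 1 to compound 3 (0.07 log units; within the scatter), which places all three substituted phenyl groups at this nitrogen level with one another, where the earlier pair offered only a single comparison. No supporting measurement bears on this result.

All three groups shown at this nitrogen are phenyl rings carrying methyl or methoxy, so the effect of a carboxylic acid, an amine or a longer alkyl chain there remains open. Also open, as far as these compounds go, is whether a change elsewhere on the shared core, such as an amine in place of the chlorine, would separate these compounds.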